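A few compounds are considered here, and "the series" means these few. Any claim that something is new, unique, unknown or untested is made for them only; others in the source may bear on it.

Measured compounds:
compound 1 `CCCOc1ccc(C(=O)Nc2cccc(C)n2)cc1` — 7500 nM
compound 2 `CCCOc1ccc(C(=O)Nc2cccc(CC)n2)cc1` — 37600 nM
compound 3 `C=CCOc1ccc(C(=O)Nc2cccc(NCCC)n2)cc1` — 14800 nM

In an in vitro assay on HEK-tsA201 cells for antagonist activity at Neuronal acetylcholine receptor; alpha4/beta2 (Homo sapiens), read by fluorescence and calcium flux (on this read-out lower numbers stand for stronger inhibition and higher numbers for weaker inhibition), compound 1 gives 7500 nM, compound 2 gives 37600 nM and compound 3 gives 14800 nM. The numbers of compound 1 and compound 3 sit within the scatter of each other; compound 2 gives a higher number than compound 3. The change from compound 1 to compound 2 is methyl in place of hydrogen on a saturated chain carbon bound to an aromatic carbon, and it made a 5.0-fold higher number from compound 1 to compound 2 (0.70 log units; beyond the scatter).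

Compound 4 `C=CCOc1ccc(C(=O)Nc2cccc(NCCCC)n2)cc1` is not yet measured. It differs from compound 3 by methyl in place of hydrogen on a saturated chain carbon, three bonds along the chain from a nitrogen on an aromatic ring. The difference between the core of compound 1 and the core of compound 3 is not broken down here. The change from compound 3 to compound 4 is the same kind of change as from compound 1 to compound 2, not the same: there the methyl enters on a saturated chain carbon bound to an aromatic carbon, here on a saturated chain carbon, three bonds along the chain from a nitrogen on an aromatic ring. A step in the same direction is expected because a 5.0-fold higher number from compound 1 to compound 2 (0.70 log units; beyond the scatter) is the only measured case of this kind, but a smaller one is estimated since the place differs: in this assay the expected step is a 1.7-fold higher number from compound 3 to compound 4 (0.23 log units; within the scatter). Compound 4 is accordingly estimated at 25000 nM, expected between 10000 nM and 70000 nM.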

Compound 4, half-maximal inhibitory concentration: 22400 nM
Beside the measured number, compound 4's estimate is 1.1-fold (0.05 log units) above it; low and high end bracket the measured number.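

In this assay, propyl to butyl on the core of compound 3 makes a 1.5-fold higher number from compound 3 to compound 4 (0.18 log units; within the scatter), so the added methyl has no readable effect on this core. The same kind of change does not carry over at a constant size between the two cores: the same change on two cores in this assay, a 5.0-fold higher number (0.70 log units; beyond the scatter) from compound 1 to compound 2 and a 1.5-fold higher number (0.18 log units; within the scatter) from compound 3 to compound 4, 3.3-fold (0.52 log units) apart, beyond the scatter of two such steps. Within the data shown here, this shows that the large step from the first pair cannot be assumed for the second, but it does not show what sets them apart, since the methyl enters at a different place in each pair, the two cores differ, and each core contributes only a single step.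

The compounds shown leave open how this assay would read a chain longer than butyl, or an amine or a carboxylic acid carried on that chain. Also open, from the compounds shown here alone, is whether the change from methyl to ethyl, made at the same place, would keep its size on a further core.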